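Same Halogen Swap on a Second Core: Compound 4

The source may report more compounds than this note shows. Statements on the series, on what has been measured and on what is new or still open speak of the compounds shown alone.

Four compounds share a common scaffold and were tested, or are to be tested, in a functional assay on HeLa cells (Homo sapiens) for antiproliferative activity, read by MTT assay, with a stated time of 48 h, in the presence of a further agent that is not named here; a higher number here means a weaker inhibitor of growth, a lower number a stronger inhibitor of growth. Compound 1 `COc1ccc(-c2nn(-c3ccccc3)cc2C(=O)NOCc2ccccc2F)cc1` is the anchor of the set; in this assay compound 1 gives 2900 nM. Compound 2 `COc1ccc(-c2nn(-c3ccccc3)cc2C(=O)NOCc2ccccc2Cl)cc1` differs from it in one spot, (chloro in place of fluoro on an aromatic carbon), and in this assay compound 2 gives 3480 nM. That change made a 1.2-fold higher number from compound 1 to compound 2 (0.08 log units; within the scatter), so the two values cannot be told apart.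

Compound 3 `O=C(NOCc1ccccc1F)c1cn(-c2ccccc2)nc1-c1ccc(F)cc1` carries a different core, and the difference between the two cores is fluoro in place of methoxy on an aromatic carbon. In this assay compound 3 gives 10300 nM. The core change made a 3.6-fold higher number from compound 1 to compound 3 (0.55 log units; beyond the scatter), and compound 3 has the highest number of the three measured compounds.

Compound 4 `O=C(NOCc1ccccc1Cl)c1cn(-c2ccccc2)nc1-c1ccc(F)cc1` is not yet measured. It stands to compound 3 as compound 2 stands to compound 1: the difference is chloro in place of fluoro on an aromatic carbon. The place of the change is described in the same words for both pairs, so this is the same change made on the other core.

The expectation rests on one observation only: the same change from compound 1 to compound 2 gave a 1.2-fold higher number from compound 1 to compound 2 (0.08 log units; within the scatter), a step that lies within the scatter. Compound 4 is therefore expected to sit close to compound 3, with an estimated step of a 1.2-fold higher number from compound 3 to compound 4 (0.07 log units; within the scatter). The estimate for compound 4 in this assay is 12000 nM, with a plausible range from 6000 nM to 25000 nM. Whether the second core behaves like the first under this swap is what the measurement will show.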

Compound 4, concentration for 50% growth inhibition: 36400 nM
Compound 4: the middle estimate sits 3.0-fold (0.48 log units) below what was measured, outside the stated range (above it).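

In this assay, replacing 2-fluorobenzyl with 2-chlorobenzyl on the second core gave a 3.5-fold higher number from compound 3 to compound 4 (0.55 log units; beyond the scatter), so a swap that could not be read on the core of compound 1 produced a real loss of growth inhibition here, and the two steps differ: the same change on two cores in this assay, a 1.2-fold higher number (0.08 log units; within the scatter) from compound 1 to compound 2 and a 3.5-fold higher number (0.55 log units; beyond the scatter) from compound 3 to compound 4, 2.9-fold (0.47 log units) apart, beyond the scatter of two such steps

The same square read the other way leads to the same conclusion, since fluoro in place of methoxy gave a 10-fold higher number from compound 2 to compound 4 (1.02 log units; beyond the scatter) with the 2-chlorobenzyl group, a larger step than the one seen with the 2-fluorobenzyl group: the same change on two cores in this assay, a 3.6-fold higher number (0.55 log units; beyond the scatter) from compound 1 to compound 3 and a 10-fold higher number (1.02 log units; beyond the scatter) from compound 2 to compound 4, 2.9-fold (0.47 log units) apart, beyond the scatter of two such steps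

In this series, then, the effect of the halogen swap did not carry over unchanged from one core to the other, and the two changes cannot be treated as simply adding up, but four compounds show only that this happened for this one pair of cores and do not show why.

From the compounds shown here alone, it remains open whether a bromo or a methyl group in place of the chloro would follow the same trend on each core. Going by these compounds, it is also open whether a core bearing a hydroxyl group or an amine in place of the methoxy would respond to the swap like the core of compound 1 or like that of compound 3.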